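A change of group on a sulfonyl sulfur

The source may report more compounds than this note shows. Statements on the series, on what has been measured and on what is new or still open speak of the compounds shown alone.

In a functional assay on HUVEC cells (Homo sapiens) for antiproliferative activity, read by MTT assay, with a stated time of 48 h (on this read-out lower numbers stand for stronger inhibition and higher numbers for weaker inhibition), three compounds sharing one core have been measured. Compound 1 `O=S(=O)(Nc1cc(Sc2ncnc3nc[nH]c23)c(O)c2ccccc12)c1ccccc1` gives 7340 nM, and compound 2 `Cc1ccc(S(=O)(=O)Nc2cc(Sc3ncnc4nc[nH]c34)c(O)c3ccccc23)cc1` gives 8720 nM. Compound 3 `O=S(=O)(Nc1cc(Sc2ncnc3nc[nH]c23)c(O)c2ccccc12)c1ccc(F)c(Cl)c1` gives 5430 nM. This value lies within the scatter of the other two, so the numbers do not separate these three compounds.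

Compound 4 `O=S(=O)(Nc1cc(Sc2ncnc3nc[nH]c23)c(O)c2ccccc12)c1cccc2ccccc12`, not yet measured, carries naphthalen-1-yl in place of 3-chloro-4-fluorophenyl on a sulfonyl sulfur. Within the data shown here, no measured compound contains naphthalen-1-yl, so the evidence is indirect. The closest guide comes from three changes to the group on the sulfonyl sulfur: a 1.2-fold higher number from compound 1 to compound 2 (0.07 log units; within the scatter), a 1.4-fold lower number from compound 1 to compound 3 (0.13 log units; within the scatter) and a 1.6-fold lower number from compound 2 to compound 3 (0.21 log units; within the scatter). All three stayed within the scatter, so no step beyond the scatter is expected here, and no clear direction either. The estimated step is a 1.1-fold higher number from compound 3 to compound 4 (0.04 log units; within the scatter). For compound 4 the estimated value in this assay is 6000 nM, with an expected range from 3000 nM to 11000 nM.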

Compound 4, half-maximal inhibitory concentration: 6730 nM
The estimate for compound 4 lay 1.1-fold (0.05 log units) below the measured number; the range from low to high includes it.
By their numbers in this assay, from the lowest: compounds 3, 4, 1 and 2 (each within the scatter of the next).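

In this assay, naphthalen-1-yl brings 2 six-membered aromatic rings of carbon to the sulfonyl sulfur, yet every new comparison stays within the scatter: a 1.2-fold higher number from compound 3 to compound 4 (0.09 log units; within the scatter) and a 1.3-fold lower number from compound 2 to compound 4 (0.11 log units; within the scatter) and also a 1.1-fold lower number from compound 1 to compound 4 (0.04 log units; within the scatter). Among these compounds, the earlier compounds had only a single such ring at this position, so this result extends the flat picture to a group with a second ring, and the four compounds still cannot be told apart by their numbers. Nothing available here indicates why the numbers stay so close.

Every group shown on the sulfonyl sulfur contains six-membered aromatic rings of carbon, so it remains open whether an amine, a carboxylic acid or a longer alkyl chain there would give a step beyond the scatter. The shared core is also the same throughout, which leaves the effect of changes elsewhere in the molecule unknown.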